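The compounds below may be only part of what the source reports. "The series", "measured", "known", "first", "only" and "open" are said of these compounds alone.

Compounds measured in a functional assay on MCF7 cells (Homo sapiens) for antiproliferative activity; a higher number here means a weaker inhibitor, a lower number a stronger inhibitor:
compound 1, `COc1cc(Cc2nc3c(N)ncnc3n2CC2CC2)cc(OC)c1OC`: 75900 nM
compound 2, `COCCn1c(Cc2cc(OC)c(OC)c(OC)c2)nc2c(N)ncnc21`: 64600 nM
compound 3, `COc1cc(Cc2nc3c(N)ncnc3n2CC(OC)OC)cc(OC)c1OC`: 72400 nM

Compound 3 stands second highest of the three numbers, but the spread is small: the steps of a 1.0-fold lower number from compound 1 to compound 3 (0.02 log units; within the scatter) and a 1.1-fold higher number from compound 2 to compound 3 (0.05 log units; within the scatter) are both within the scatter, as is a 1.2-fold lower number from compound 1 to compound 2 (0.07 log units; within the scatter). The three compounds share the same core and differ only in what sits on the saturated chain carbon bound to the aromatic nitrogen, and none of those exchanges moved the number.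

Compound 4, `C/C=C/Cn1c(Cc2cc(OC)c(OC)c(OC)c2)nc2c(N)ncnc21`, continues this series at the same position. Compared with compound 3: prop-1-en-1-yl in place of dimethoxymethyl on a saturated chain carbon bound to an aromatic nitrogen. The measured steps that bear on it are exactly those three, since each of them swaps the group at the same place; all were flat. Prop-1-en-1-yl has not yet been tried here, and a ring, two ether oxygens and a plain chain have so far given the same result, so no step beyond the scatter is expected in this assay.

The expected step is a 1.0-fold lower number from compound 3 to compound 4 (0.01 log units; within the scatter). Compound 4 is therefore estimated at 70000 nM, with a range from 35000 nM to 140000 nM.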

Compound 4, half-maximal inhibitory concentration: 51300 nM
Compound 4: the middle estimate sits 1.4-fold (0.13 log units) above what was measured; the measured number falls inside the stated range.
By their numbers in this assay, from the lowest: compounds 4, 2, 3 and 1 (each within the scatter of the next).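

In this assay the steps of a 1.4-fold lower number from compound 3 to compound 4 (0.15 log units; within the scatter) and a 1.3-fold lower number from compound 2 to compound 4 (0.10 log units; within the scatter) and a 1.5-fold lower number from compound 1 to compound 4 (0.17 log units; within the scatter) all lie within the scatter, so the new group does not separate from the three earlier ones. The position therefore accepts prop-1-en-1-yl, which brings a double bond outside aromatic rings to the series, with no step beyond the scatter; the exchange from compound 3 also takes out both oxygens and two heavy atoms and still leaves the number level. Nothing available explains why the numbers at this position stay so close, and no supporting measurement bears on this result.

With four compounds lying this close together, the series shows no group at this place that moves the number, and an amine, a carboxylic acid or a longer chain such as hexyl could test whether any substituent here gives a step beyond the scatter. On these data alone, whether a change elsewhere on the shared core would move the number in this assay also stays open.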